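The source may report more compounds than this note shows. Statements on the series, on what has been measured and on what is new or still open speak of the compounds shown alone.

Compound 1 `O=C(CCCCCCNC(=O)C(O)(O)C(F)(F)F)Nc1ccc(Cl)cc1` is the weakest binder among three aminoheptanoyl hydrates measured in an assay on isolated protein for inhibition of histone deacetylase 4 (Homo sapiens), read by chemiluminescence, with a stated time of 3 h (on this read-out higher numbers stand for weaker inhibition and lower numbers for stronger inhibition), where compound 1 gives 2700000 nM. Its nearest neighbour, compound 2 `O=C(CCCCCCNC(=O)C(O)(O)C(F)(F)F)Nc1ncc(-c2ccccc2)s1`, gives 2500000 nM, and compound 3 `O=C(CCCCCCNC(=O)C(O)(O)C(F)(F)F)Nc1ncc(-c2ccc(Br)cc2)s1` gives 1700000 nM; all three values sit within the scatter of one another, so none is distinguished from the rest.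

The step under study replaces the chloro of compound 1 with a phenyl on the same aromatic carbon, giving compound 4 `O=C(CCCCCCNC(=O)C(O)(O)C(F)(F)F)Nc1ccc(-c2ccccc2)cc1`. The change is counted as phenyl in place of chloro on an aromatic carbon.

Within the data shown here, only one measured step speaks to an added group on the terminal aromatic ring: a 1.5-fold lower number from compound 2 to compound 3 (0.17 log units; within the scatter), a change that did not rise above the scatter. The pair of compound 1 and compound 2 differ in the whole aryl part of the shared core, yet their values are barely apart. Nothing in these three compounds suggests that the terminal aromatic region governs the number strongly, so no step beyond the scatter is expected in this assay for compound 4, and if any drift occurs it is expected toward a slightly lower number, in line with the small step from compound 2 to compound 3.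

Compound 4 is therefore estimated at 2000000 nM, with a range from 700000 nM to 6000000 nM, meaning an expected step of a 1.4-fold lower number from compound 1 to compound 4 (0.13 log units; within the scatter).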

Compound 4, half-maximal inhibitory concentration: 1100000 nM
Compound 4: the middle estimate sits 1.8-fold (0.26 log units) above what was measured; measured number inside the range.
By their numbers in this assay, from the lowest: compounds 4, 3, 2 and 1 (each within the scatter of the next, the first and the last beyond it).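

In this assay, phenyl in place of chloro on an aromatic carbon, para to a large group, gives a 2.5-fold lower number from compound 1 to compound 4 (0.39 log units; beyond the scatter), a modest step but one that lies beyond the scatter. Among these compounds, the only earlier step on an aromatic carbon, bromo in place of hydrogen, gave a 1.5-fold lower number from compound 2 to compound 3 (0.17 log units; within the scatter) and stayed within the scatter, so this is the first sign that a change of group on the terminal aromatic ring can move the number at all, even though compound 4 still gives 1100000 nM. Nothing measured here speaks to why the number moves with this change.

The compounds shown leave open whether the step belongs to the aromatic ring of the phenyl or simply to its 6 heavy atoms, which a cyclohexyl group at the same place would help to separate. They also leave open whether a further group on the added phenyl, such as an amine or a carboxylic acid, would carry the number further down or bring it back up.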